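This account rests on a few compounds, and the source may have more. Where it says the series, first, only, none or still open, it means among the compounds named here.

Compound 1, `Nc1sc(-c2ccccc2)cc1C(=O)c1ccc(Cl)cc1`: in an assay on CHO cells for positive allosteric modulation of adenosine receptor A1 (Homo sapiens), read by ERK phosphorylation, tested at 3 uM (a higher number here means a weaker effect of the compound at the concentration tested, a lower number a stronger effect), compound 1 gives 46%.
Compound 2, `CN(C)c1ccc(-c2cc(C(=O)c3ccc(Cl)cc3)c(N)s2)cc1`: in this assay compound 2 gives 56%.

Among the measured compounds shown here, compound 2 holds the higher of the two numbers, but the only comparison available is the step of a number 10 percentage points higher from compound 1 to compound 2 (within the scatter), which the usual scatter of such measurements covers, so the two values cannot be told apart. The step now followed leads from compound 2 to compound 3, `Nc1sc(-c2ccc(C(=O)O)cc2)cc1C(=O)c1ccc(Cl)cc1`, which has not yet been measured. The change is carboxy in place of dimethylamino on an aromatic carbon. A single measured step exists in this series, a number 10 percentage points higher from compound 1 to compound 2 (within the scatter), the exchange of hydrogen for dimethylamino at the same place; it bears on the new step only in showing that a group there left the number within the scatter. For the measured compounds named here, the present change removes that dimethylamino and brings in a carboxy, for which no measured analogue exists. Compound 3 is therefore expected near the two known values, with an estimated step of a number 2 percentage points higher from compound 2 to compound 3 (within the scatter) and wide uncertainty. The estimate for compound 3 is 58%, expected to fall between 40% and 78%.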

Compound 3, a percentage reported as activity, at one concentration (the size of the read-out at that concentration, not a potency): 27%
Compound 3: the middle estimate sits 31 percentage points above what was measured; measured number outside the range, below it.
By their numbers in this assay, from the lowest: compound 3; then compounds 1 and 2 (each within the scatter of the next).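

In this assay, this carbon, para to a large group, now proves able to shift the number beyond the scatter, which the exchange of hydrogen for dimethylamino had not shown: carboxy in place of dimethylamino gives a number 29 percentage points lower from compound 2 to compound 3 (beyond the scatter), and carboxy in place of hydrogen gives a number 19 percentage points lower from compound 1 to compound 3 (beyond the scatter). As a lower number here means a stronger effect, carboxy alone among the groups shown stands apart, and it does so against both compounds, so the finding does not rest on the choice of comparison. Nothing available here accounts for why this group differs from the other two.

The compounds shown leave open whether the stronger effect would persist with a related group at this place, such as a methyl ester, a primary amide or a tetrazole, or with a longer chain ending in a carboxylic acid. They also leave open whether a carboxy on another carbon of this ring would give a similar number, or whether this step would hold with a different group in place of the chlorine on the other ring.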